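Moving the Methyl: From Compound 1 to Compound 3

The source may hold more compounds than are shown below. What is called first, only, known or untested is meant among the compounds shown, and "the series" means these compounds.

Compound 1 `C=CCn1c(=O)/c(=C\c2cccc(C)c2)[nH]c(=O)/c1=C\c1ccccc1OC`: 19300 nM
Compound 2 `C=CCn1c(=O)/c(=C\c2ccc(F)c(Br)c2)[nH]c(=O)/c1=C\c1ccccc1OC`: "not active" (no number reported)

Within the data shown here, in a functional assay on HeLa cells (Homo sapiens) for cytotoxicity, read by CCK-8 assay, with a stated time of 72 h (on this read-out higher numbers stand for weaker inhibition and lower numbers for stronger inhibition), compound 1 gives 19300 nM, the only number that has been reported; compound 2 is reported without a number as "not active" (no number reported). Compound 3 `C=CCn1c(=O)/c(=C\c2ccc(C)cc2)[nH]c(=O)/c1=C\c1ccccc1OC` differs from compound 1 by 4-methylphenyl in place of 3-methylphenyl on a double-bonded chain carbon bound to an aromatic carbon. Among the measured compounds shown here, no step between measured compounds is known here, so the expected step from compound 1 to compound 3 is a 1.0-fold higher number from compound 1 to compound 3 (0.02 log units; within the scatter), which is expected to stay within the scatter of repeated measurements. Compound 3 is therefore estimated at 20000 nM, with a range from 7000 nM to 60000 nM.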

Compound 3, half-maximal inhibitory concentration: "not active" (no number reported)
Compound 3: no number reported, and the estimate cannot be compared.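

Among these compounds, compound 3, like compound 2, carries no number, so no step from compound 1 to compound 3 can be read. The compounds shown leave open how 4-methylphenyl and 3-methylphenyl compare in this assay, and no evidence here bears on this result.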